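Moving the hydroxy group: compound 2 to compound 3

A few compounds are considered here, and "the series" means these few. Any claim that something is new, unique, unknown or untested is made for them only; others in the source may bear on it.

Measured in a physicochemical assay for solubility, read by HPLC, in phosphate buffer, with a stated time of 24 h, at pH 7.4; on this read-out higher numbers stand for higher solubility and lower numbers for lower solubility:
- compound 1 `COc1ccc(Cn2nnc(O)c2C(=O)Nc2cccc(-c3ccccc3)c2)cc1`: < 1000 nM (a limit, not a number)
- compound 2 `COc1ccc(Cn2nnc(O)c2C(=O)Nc2cccc(-c3ccc(O)cc3)c2)cc1`: 2050 nM

Going by the values given here, compound 2 gives the only actual number so far, 2050 nM. Its standing can be judged only against the limit held by compound 1.

Compound 3 `COc1ccc(Cn2nnc(O)c2C(=O)Nc2cccc(-c3cccc(O)c3)c2)cc1` is the next to be read. The change is 3-hydroxyphenyl in place of 4-hydroxyphenyl on an aromatic carbon, with 3-hydroxyphenyl in place of 4-hydroxyphenyl, the hydroxy group now meta to a large group.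

Among the compounds with values here, the sole measured step, an at least 2.0-fold higher number from compound 1 to compound 2 (0.31 log units; beyond the scatter), came with hydroxy in place of hydrogen on an aromatic carbon. It bears on the new change only in part, since it concerns adding that group and not moving it, and compound 3 still carries the group. Within the data shown here, with compound 2 at 2050 nM as the anchor and no measured step for such a move, no shift beyond the scatter is expected in this assay.

The expected change is a 1.0-fold lower number from compound 2 to compound 3 (0.01 log units; within the scatter). For compound 3 the estimate is 2000 nM, with an expected range of 1000 nM to 4500 nM.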

Compound 3, solubility: 40300 nM
Compound 3: middle estimate off by 20-fold (1.30 log units), on the low side; measured number outside the range, above it.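

In this assay, exchanging 4-hydroxyphenyl for 3-hydroxyphenyl, with the same atoms and the same counts of donors and acceptors on the group, gives a 20-fold higher number from compound 2 to compound 3 (1.29 log units; beyond the scatter), so the composition of the group does not by itself set the read-out. Measured against the plain phenyl of compound 1, adding the hydroxy group as 3-hydroxyphenyl gives an at least 40-fold higher number from compound 1 to compound 3 (1.60 log units; beyond the scatter), and the size of what this addition does at this position therefore depends on where the hydroxy group stands on the ring. This step is a bound and not an exact size, since compound 1 holds a limit and not a number: the limit of < 1000 nM in this assay, at which 1 of the 3 values shown sits.

The compounds shown give no measured cause for the gap between 3-hydroxyphenyl and 4-hydroxyphenyl, and they cover only this one read-out. On these data alone, whether the higher number belongs to the hydroxy group itself or would also come with another group meta to a large group, such as an amine or a carboxylic acid, remains open.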